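From a Cyclohexenyl Ether to a Cyclobutyl Ether

The compounds below may be only part of what the source reports. "The series", "measured", "known", "first", "only" and "open" are said of these compounds alone.

Compound 1 `CCCOc1nc(N)nc2[nH]cnc12` and compound 2 `Nc1nc(OCC2CC=CCC2)c2[nH]cnc2n1` share the same core and differ only in the group carried on the ether oxygen. In an assay on HT-29 cells with Methylated-DNA--protein-cysteine methyltransferase (Homo sapiens) as the target (a lower number here means a stronger inhibitor, a higher number a weaker inhibitor), compound 1 gives > 1000000 nM, which is a limit of the assay rather than a number. In this assay compound 2 likewise gives > 1000000 nM, again a limit and not a measured number. Among the measured compounds shown here, compound 2 therefore stands at the limit, as does the only other value shown (the limit of > 1000000 nM in this assay, at which 2 of the 2 values shown sit). Compound 3 `Nc1nc(OCC2CCC2)c2[nH]cnc2n1` carries cyclobutyl in place of cyclohex-3-en-1-yl on a saturated chain carbon bound to an oxygen on an aromatic ring. For the measured compounds named here, no measured step connects compound 2 and compound 3, and both measured values are limits. No shift beyond the scatter is expected, and the estimated step is a number no higher from compound 2 to compound 3 (the limit leaves the size open). In this assay compound 3 is expected to give about 1000000 nM, within a range from 300000 nM to 3000000 nM, and most probably it is reported only as a limit once more.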

Compound 3, half-maximal inhibitory concentration: > 1000000 nM
Compound 3 was reported as a limit (the forecaster's own chance of this, stated with the estimate: 85%); the middle value sits exactly at the limit.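

In this assay compound 3 gives > 1000000 nM, which is a limit of the assay and not a number. Among the compounds shown here, with compound 2 also at a limit, no step between compound 2 and compound 3 can be read. The compounds shown leave open what change in the group on the ether oxygen, if any, would yield a measurable value.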